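Swapping chloro for methoxy on compound 3

The source may hold more compounds than are shown below. What is called first, only, known or untested is meant among the compounds shown, and "the series" means these compounds.

Measured in a functional assay on A549 cells (Homo sapiens) for cytotoxicity, read by MTT assay, with a stated time of 72 h; on this read-out higher numbers stand for weaker inhibition and lower numbers for stronger inhibition:
- Compound 1 `COc1cccc(/C=C2\CCC/C(=C\c3ccc(Cl)cc3)C2=O)c1OC`: > 20000 nM (a limit)
- Compound 2 `COc1cccc(/C=C2\CCC/C(=C\c3ccc(O)c(Cl)c3)C2=O)c1OC`: > 20000 nM (a limit)
- Compound 3 `COc1ccc(/C=C2\CCC/C(=C\c3cccc(Cl)c3)C2=O)cc1OC`: 11000 nM

Going by the values given here, compound 3 holds the only actual number of the three. Compound 1 and compound 2 both rest on (the limit of > 20000 nM in this assay, at which 2 of the 3 values shown sit).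

Compound 4 `COc1cccc(/C=C2\CCC/C(=C\c3ccc(OC)c(OC)c3)C2=O)c1` differs from compound 3 in one place: methoxy in place of chloro on an aromatic carbon. A 3-chlorophenyl thus becomes a 3-methoxyphenyl. Among the compounds with values here, the only measured step is a step that the two limits leave unreadable from compound 1 to compound 2, and it changes a different group, so it offers no size to carry over. The expectation therefore stays anchored on compound 3 at 11000 nM, with no step beyond the scatter expected in this assay, in either direction. The expected change is a 1.1-fold higher number from compound 3 to compound 4 (0.04 log units; within the scatter). For compound 4 the estimate is 12000 nM, with an expected range of 5000 nM to 20000 nM.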

Compound 4, half-maximal inhibitory concentration: 6700 nM
Compound 4: the middle estimate sits 1.8-fold (0.25 log units) above what was measured; low and high end bracket the measured number.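

In this assay, methoxy in place of chloro on this aromatic carbon gives a 1.6-fold lower number from compound 3 to compound 4 (0.22 log units; within the scatter), so this pair shows no real difference between the two groups. Going by these compounds alone, this is the first step with a readable size. The earlier step between compound 1 and compound 2 cannot be read, since both rest on the same limit: the limit of > 20000 nM in this assay, at which 2 of the 4 values shown sit.

As far as these compounds go, what an amine or a carboxylic acid on this carbon would do remains open. So does whether chloro and methoxy would also read alike elsewhere on the ring.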